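A few compounds are considered here, and "the series" means these few. Any claim that something is new, unique, unknown or untested is made for them only; others in the source may bear on it.

Measured compounds:
- compound 1, `Cn1c(-c2ccccc2)cnc1NC(=O)c1ccccc1Cl`: > 50000 nM
- compound 2, `COc1ccc(-c2cnc(NC(=O)c3ccc(F)cc3)n2-c2ccccc2)cc1`: 8800 nM
- compound 3, `Cn1c(-c2cccc(Cl)c2)cnc1NC(=O)c1ncc[nH]1`: 55000 nM

All three were tested in a toxicity assay on THP-1 cells (Homo sapiens) for inhibition; on this read-out lower numbers stand for higher toxicity in this test and higher numbers for lower toxicity in this test. Compound 1 gives > 50000 nM, and this is a limit of the assay rather than a measured number. Among the values shown, compound 1 sits at the top end of the range, as stated by the limit of > 50000 nM in this assay, at which 1 of the 3 values shown sits. Compound 3 gives 55000 nM, and compound 2 gives 8800 nM. Compound 2 therefore stands lower on the read-out than compound 3, while compound 1 and compound 3 both sit near the high end.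

The unmeasured compound 4, `Cc1cccc(C(=O)Nc2ncc(-c3ccccc3)n2C)c1`, differs from compound 1 in one place: 3-methylphenyl in place of 2-chlorophenyl on a carbonyl carbon. For the measured compounds named here, no measured pair shows exactly this kind of exchange, so there is no counted step to lean on. Given that compound 1 gives > 50000 nM and compound 3 gives 55000 nM, the expectation is a change no larger than the scatter, in no particular direction. Compound 4 is expected to give about 50000 nM, most likely between 20000 nM and 100000 nM, meaning an expected step of a number no higher from compound 1 to compound 4 (the limit leaves the size open).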

Compound 4, half-maximal cytotoxic concentration: > 50000 nM
Compound 4: a limit, no number (the forecaster's own chance of this, stated with the estimate: 55%); the middle value sits exactly at the limit.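

For the compounds shown here, compound 1 and compound 4 each give only a limit of the assay, not a number, so no step between them can be read: the limit of > 50000 nM in this assay, at which 2 of the 4 values shown sit.

The compounds shown leave open whether 3-methylphenyl in place of 2-chlorophenyl on a carbonyl carbon changes the result in this assay at all.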